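Permeability Across Three Ureas and Carbamates, and a Fourth

This account rests on a few compounds, and the source may have more. Where it says the series, first, only, none or still open, it means among the compounds named here.

Measured compounds and their values in an ADME assay on Caco-2 cells (Homo sapiens) for permeability, in the apical to basolateral direction; on this read-out higher numbers stand for higher permeability and lower numbers for lower permeability:
compound 1 `Cn1cncc1CN1CC(N(CC2CCN(C(=O)NC(C)(C)C)CC2)S(=O)(=O)c2ccccn2)Cc2cc(C#N)ccc21` gives 0.6 10^-6 cm/s
compound 2 `CC(C)OC(=O)N1CCC(CN(C2Cc3cc(C#N)ccc3N(Cc3cncn3C)C2)S(=O)(=O)c2ccccn2)CC1` gives 1 10^-6 cm/s
compound 3 `CCNC(=O)N1CCC(CN(C2Cc3cc(C#N)ccc3N(Cc3cncn3C)C2)S(=O)(=O)c2ccccn2)CC1` gives 0.6 10^-6 cm/s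

All three share one core and differ only in the group on the carbonyl carbon that sits on the ring nitrogen. In this assay compound 3 stands level with compound 1, and the two together hold the lowest numbers of the three, while compound 2 sits a 1.7-fold lower number from compound 2 to compound 3 (0.22 log units; within the scatter) above compound 3, a gap that lies within the scatter. The step of a 1.7-fold higher number from compound 1 to compound 2 (0.22 log units; within the scatter) tells the same story: swapping an amino group for an alkoxy group at this position moved the number only within the scatter.

Compound 4 `Cn1cncc1CN1CC(N(CC2CCN(C(=O)OCc3ccccc3)CC2)S(=O)(=O)c2ccccn2)Cc2cc(C#N)ccc21` is not yet measured. The change from compound 3 is benzyloxy in place of ethylamino on a carbonyl carbon. Compound 4 thus carries an alkoxycarbonyl group, as compound 2 does, though the benzyloxy group is larger and brings a six-membered aromatic ring. The two steps that bear on this, a 1.7-fold lower number from compound 2 to compound 3 (0.22 log units; within the scatter) and a 1.7-fold higher number from compound 1 to compound 2 (0.22 log units; within the scatter), were both small, so the expected step of a 2.0-fold higher number from compound 3 to compound 4 (0.30 log units; within the scatter) is also modest and, if anything, upward. Compound 4 is therefore estimated at 1.2 10^-6 cm/s, with a range from 0.5 10^-6 cm/s to 3 10^-6 cm/s.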

Compound 4, apparent permeability: 1 10^-6 cm/s
The estimate for compound 4 lay 1.2-fold (0.08 log units) above the measured number; low and high end bracket the measured number.
By their numbers in this assay, from the lowest: compounds 1, 3, 2 and 4 (each within the scatter of the next).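

In this assay benzyloxy gives a 1.7-fold higher number from compound 3 to compound 4 (0.22 log units; within the scatter) when it replaces ethylamino and a 1.7-fold higher number from compound 1 to compound 4 (0.22 log units; within the scatter) when it replaces (tert-butyl)amino, while putting benzyl on the oxygen in place of isopropyl gives no change at the digits printed from compound 2 to compound 4 (within the scatter) for the carbamate pair. So this place on the carbonyl carbon took a group of 8 heavy atoms with a six-membered aromatic ring, and lost the hydrogen-bond donor of ethylamino, with no step beyond the scatter among these four compounds. Nothing measured here speaks to why these steps are so small.

The compounds shown leave open what a carboxylic acid or a free amine carried on this carbonyl group would do to the number. They also leave open whether a longer chain, such as phenylpropyl on the oxygen, would give a step beyond the scatter.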